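The compounds below may be only part of what the source reports. "The series", "measured", "known", "first", "only" and "open" are said of these compounds alone.

Compound 1 `C=C[C@@](C)(/C=C/c1ccc(O)cc1)CC/C=C/C(=O)OCC` and compound 2 `C=C[C@@](C)(/C=C/c1ccc(O)cc1)CC/C=C/C(=O)OCc1ccccc1` share one core, while compound 3 `C=C[C@@](C)(/C=C/c1ccc(O)c(/C=C/C(=O)OCC)c1)CCC=C(C)C` and compound 4 `C=C[C@@](C)(/C=C/c1ccc(O)c(/C=C/C(=O)OCc2ccccc2)c1)CCC=C(C)C` share another; the difference between the two cores is not broken down here. In a functional assay on SEM cells (Homo sapiens) for cytotoxicity, with a stated time of 72 h (a higher number here means that more compound is needed for the effect, a lower number that less compound is needed), compound 1 gives > 36600 nM, which is a limit of the assay and not a number. In this assay compound 2 gives > 36600 nM, again a limit. Compound 3 likewise gives > 36600 nM, a limit. The change from compound 1 to compound 2 is phenyl in place of methyl on a saturated chain carbon bound to an oxygen next to a carbonyl group, and its step is a step that the two limits leave unreadable from compound 1 to compound 2. Compound 4 carries the same change, (phenyl in place of methyl on a saturated chain carbon bound to an oxygen next to a carbonyl group). The expected step is a step that the limit leaves unreadable from compound 3 to compound 4, resting on a step that the two limits leave unreadable from compound 1 to compound 2 and on (the limit of > 36600 nM in this assay, at which 3 of the 3 values shown sit). Compound 4 is therefore expected to give 50000 nM, most likely once more only a limit.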

Compound 4, half-maximal effective concentration: > 36600 nM
Compound 4: no number, only a limit; the forecaster's own chance of this, stated with the estimate: 85%; the middle value lies beyond the limit too.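

In this assay compound 4 gives > 36600 nM, a limit and not a number, so no step can be read between compound 3 and compound 4. Whether phenyl in place of methyl changes the effect at all stays open: the limit of > 36600 nM in this assay, at which 4 of the 4 values shown sit.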